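Methoxycarbonyl to ethoxycarbonyl on compound 1

The compounds below may be only part of what the source reports. "The series", "measured", "known", "first", "only" and "open" are said of these compounds alone.

Among the measured compounds shown here, in a functional assay on HeLa cells (Homo sapiens) for cytotoxicity, read by MTT assay, with a stated time of 72 h (a higher number here means a weaker inhibitor, a lower number a stronger inhibitor), compound 1 `COC(=O)c1sc2cc(OC)ccc2c1Nc1cc(OC)c(OC)c(OC)c1` gives 0.28 nM, at the low end of the numbers so far. Compound 2 `COC(=O)c1sc2cc(C)ccc2c1Nc1cc(OC)c(OC)c(OC)c1`, at 0.31 nM, cannot be told apart from it, while compound 3 `COC(=O)c1sc2ccccc2c1Nc1cc(OC)c(OC)c(OC)c1` stands far higher at 427 nM.

Compound 4 `CCOC(=O)c1sc2cc(OC)ccc2c1Nc1cc(OC)c(OC)c(OC)c1` keeps the core of compound 1 and differs in one place: methyl in place of hydrogen on a saturated chain carbon bound to an oxygen next to a carbonyl group. This turns methoxycarbonyl into ethoxycarbonyl.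

For the measured compounds named here, no measured step touches this group, as all three concern a substituent on an aromatic carbon. With methyl in place of methoxy, the step of a 1.1-fold higher number from compound 1 to compound 2 (0.04 log units; within the scatter) stayed small. With hydrogen in place of either group, the steps of a 1500-fold higher number from compound 1 to compound 3 (3.18 log units; beyond the scatter) and a 1400-fold higher number from compound 2 to compound 3 (3.14 log units; beyond the scatter) were large. Going by the values given here, these steps show only that a single small change can matter greatly in this assay, so they widen the uncertainty without setting a direction.

A modest rise towards a weaker number is assumed here, and the expected step is a 2.9-fold higher number from compound 1 to compound 4 (0.46 log units; beyond the scatter). The estimate for compound 4 is 0.8 nM, with an expected range from 0.15 nM to 8 nM.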

Compound 4, half-maximal inhibitory concentration: 0.56 nM
Estimate against measurement, compound 4: 1.4-fold (0.15 log units) above; the measured number falls inside the stated range.
By their numbers in this assay, from the lowest: compounds 1, 2 and 4 (each within the scatter of the next); then compound 3.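

Among the compounds shown here, until this result, every measured step concerned a substituent on an aromatic carbon; compound 4 gives the first reading at the methoxycarbonyl group. In this assay, changing it to ethoxycarbonyl gives a 2.0-fold higher number from compound 1 to compound 4 (0.30 log units; within the scatter), so this added methyl on a saturated chain carbon bound to an oxygen next to a carbonyl group makes no difference that can be told from the scatter, in contrast to the large 1500-fold higher number from compound 1 to compound 3 (3.18 log units; beyond the scatter) seen at the aromatic carbon. No measurement shown here explains why the two places differ so much.

Going by these compounds, a longer chain such as propoxycarbonyl, or a carboxylic acid or an amide in place of the ester, remains open. A single added methyl cannot show how much larger a change this group would accept before the number moves.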